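The source may report more compounds than this note shows. Statements on the series, on what has been measured and on what is new or still open speak of the compounds shown alone.

In an assay on HEK293 cells for agonist activity at transient receptor potential cation channel subfamily M member 8 (Homo sapiens), read by fluorescence and calcium flux, with a stated time of 15 min (a lower number here means that less compound is needed, a higher number that more compound is needed for the effect), the measured compounds give:

Compound 1 `CCN(Cc1c[nH]nn1)C(=O)COc1ccc(C)cc1`: 31100 nM
Compound 2 `CCN(Cc1ccsc1)C(=O)COc1ccc(C)cc1`: 88 nM
Compound 3 `CCN(Cc1ccc(C)s1)C(=O)COc1ccc(C)cc1`: 178 nM

Compound 3 stands second highest of these three numbers in this assay: a 2.0-fold higher number from compound 2 to compound 3 (0.31 log units; beyond the scatter) is modest, whereas a 170-fold lower number from compound 1 to compound 3 (2.24 log units; beyond the scatter) is large. Compound 4 `CCN(Cc1ccccn1)C(=O)COc1ccc(C)cc1` is not yet measured and differs from compound 3 by pyridin-2-yl in place of 5-methylthiophen-2-yl on a saturated chain carbon bound to an amide-type nitrogen. Within the data shown here, no measured step exchanges a five-membered ring for a six-membered one; the nearest guides are the large 350-fold lower number from compound 1 to compound 2 (2.55 log units; beyond the scatter) and a 170-fold lower number from compound 1 to compound 3 (2.24 log units; beyond the scatter), which show that the ring at this position matters greatly, and the modest 2.0-fold higher number from compound 2 to compound 3 (0.31 log units; beyond the scatter). A modest rise is therefore expected, a 3.4-fold higher number from compound 3 to compound 4 (0.53 log units; beyond the scatter), with wide uncertainty. Compound 4 is estimated at 600 nM, within 120 nM to 4000 nM.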

Compound 4, half-maximal effective concentration: 16000 nM
For compound 4 the middle estimate is 27-fold (1.43 log units) below the measured one; the whole stated range lies below it.
By their numbers in this assay, from the lowest: compound 2; then compound 3; then compounds 4 and 1 (each within the scatter of the next).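

The swap to pyridin-2-yl keeps the count of heavy atoms of 5-methylthiophen-2-yl, yet the number rises steeply (a 90-fold higher number from compound 3 to compound 4 (1.95 log units; beyond the scatter)), and the same holds against thiophen-3-yl (a 180-fold higher number from compound 2 to compound 4 (2.26 log units; beyond the scatter)). A six-membered aromatic ring at this place therefore gives no gain over 1H-1,2,3-triazol-4-yl (a 1.9-fold lower number from compound 1 to compound 4 (0.29 log units; within the scatter)), so not every aromatic ring is tolerated here. Ring size and hetero atom change together in this step, so their shares cannot be separated.

From the compounds shown here alone, whether a plain phenyl ring, without a ring nitrogen, would match the thiophenes remains open. Nothing available explains the loss.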